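A few compounds are considered here, and "the series" means these few. Any claim that something is new, unique, unknown or untested is made for them only; others in the source may bear on it.

In a functional assay on MDA-MB-435 cells (Homo sapiens) for cytotoxicity, read by MTT assay, with a stated time of 72 h (on this read-out higher numbers stand for weaker inhibition and lower numbers for stronger inhibition), compound 3 `N[C@H]1CC[C@H](Nc2c(C(=O)NCc3ccc(Cl)cc3)nc(Br)c3cccnc23)CC1` gives 1000 nM, the lower of the two exact numbers, and compound 2 `N[C@H]1CC[C@H](Nc2c(C(=O)NCc3ccc(F)cc3)nc(Br)c3cccnc23)CC1` gives 6000 nM. Compound 1 `N[C@H]1CC[C@H](Nc2c(C(=O)NCc3ccco3)nc(Br)c3cccnc23)CC1` shows > 10000 nM, which is a limit of the assay. Compound 4 `COC(=O)c1nc(Br)c2cccnc2c1N[C@H]1CC[C@H](N)CC1` has methoxy in place of (4-chlorobenzyl)amino on a carbonyl carbon. The nearest evidence comes from steps that keep the amide but alter its outer group: an at least 10-fold lower number from compound 1 to compound 3 (1.00 log units; beyond the scatter), an at least 1.6-fold lower number from compound 1 to compound 2 (0.22 log units; that floor lies within the scatter) and a 6.0-fold lower number from compound 2 to compound 3 (0.78 log units; beyond the scatter). Among the compounds with values here, no measured step removes that group entirely. Within the data shown here, compound 3 holds the lowest number, and even the single swap in a 6.0-fold lower number from compound 2 to compound 3 (0.78 log units; beyond the scatter) moved the result, so losing the whole group should raise the number. The expected step is a 5.0-fold higher number from compound 3 to compound 4 (0.70 log units; beyond the scatter). For compound 4 the estimated value is 5000 nM, with an expected range of 1500 nM to 20000 nM.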

Compound 4, half-maximal inhibitory concentration: > 20000 nM
Compound 4: only a limit was reported (the forecaster's own chance of this, stated with the estimate: 35%); at least 4.0-fold (0.60 log units) between middle value and limit.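

Compound 4 gives > 20000 nM as a limit of the assay, not a number. Even so, in this assay methoxy in place of the benzylamino-type group on this carbonyl carbon gives an at least 20-fold higher number from compound 3 to compound 4 (1.30 log units; beyond the scatter) and an at least 3.3-fold higher number from compound 2 to compound 4 (0.52 log units; beyond the scatter) as well, so the number here depends on more than the swap of one halogen for another on the ring. The step from compound 1 to compound 4 cannot be read, as both values are limits. Still open, going by these compounds, is which part of the lost group counts: the ring, the chain carbon or the amide hydrogen. A methylamino group or a carboxylic acid on this carbonyl carbon would begin to separate these.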